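The source may report more compounds than this note shows. Statements on the series, on what has been measured and on what is new or still open speak of the compounds shown alone.

Three compounds that share one core have been compared in a functional assay on PC-3 cells (Homo sapiens) for antiproliferative activity, read by MTT assay; on this read-out lower numbers stand for stronger inhibition and higher numbers for weaker inhibition. Compound 1 `Cn1c(=O)c(=O)n(C2CCCC2)c2nc(N/N=C/c3ccccc3)ncc21` carries a plain phenyl on the carbon that is double-bonded to nitrogen, and in this assay compound 1 gives 48200 nM. Compound 2 `Cn1c(=O)c(=O)n(C2CCCC2)c2nc(N/N=C/c3ccc(Cl)cc3)ncc21` bears a 4-chlorophenyl in that place, and in this assay compound 2 gives 8420 nM. Compound 3 `Cn1c(=O)c(=O)n(C2CCCC2)c2nc(N/N=C/c3cccs3)ncc21` has a thiophen-2-yl there, and in this assay compound 3 gives 75600 nM, the highest of the three numbers; its separation from compound 1 lies within the scatter, while compound 2 stands apart by a clear margin.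

Compound 4 `Cn1c(=O)c(=O)n(C2CCCC2)c2nc(N/N=C/c3ccc(F)cc3Cl)ncc21` has not yet been measured. Its change from compound 3 is 2-chloro-4-fluorophenyl in place of thiophen-2-yl on a carbon with a double bond to nitrogen. Among the measured compounds shown here, two measured steps bear on this. One is a 5.7-fold lower number from compound 1 to compound 2 (0.76 log units; beyond the scatter), showing that a chloro on the phenyl lowered the number modestly. The other is a 9.0-fold higher number from compound 2 to compound 3 (0.95 log units; beyond the scatter), showing that the thiophen-2-yl sits well above the chlorinated phenyl. The change to compound 4 reverses that second step and places a phenyl carrying both chloro and fluoro, so a modest decrease is expected, roughly a 5.0-fold lower number from compound 3 to compound 4 (0.70 log units; beyond the scatter). The estimate for compound 4 is therefore 15000 nM, with a range from 4000 nM to 50000 nM.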

Compound 4, half-maximal inhibitory concentration: 15200 nM
Compound 4: middle estimate off by 1.0-fold (0.01 log units), on the low side, within the range that was stated.
By their numbers in this assay, from the lowest: compounds 2 and 4 (each within the scatter of the next); then compounds 1 and 3 (each within the scatter of the next).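

In this assay, the lower number seen with 4-chlorophenyl is not unique to that one group: the 2-chloro-4-fluorophenyl of compound 4 also falls beyond the scatter from the plain phenyl, with a 3.2-fold lower number from compound 1 to compound 4 (0.50 log units; beyond the scatter), and from the thiophen-2-yl, with a 5.0-fold lower number from compound 3 to compound 4 (0.70 log units; beyond the scatter). Exchanging one halogenated phenyl for the other gives a 1.8-fold higher number from compound 2 to compound 4 (0.26 log units; within the scatter), which lies within the scatter, so this position tolerates a second halogen and a different arrangement of substituents on the ring without any readable change in the number. Nothing available here explains why these groups give different numbers.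

Since compound 4 carries chloro and fluoro together, the share of each cannot be separated, and a phenyl carrying fluoro alone would be needed to begin telling them apart. Going by these compounds, it also remains open how this carbon with a double bond to nitrogen would respond to a phenyl bearing an amine or a carboxylic acid, or to a longer carbon chain in place of the aromatic ring.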